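This account rests on a few compounds, and the source may have more. Where it says the series, first, only, none or still open, it means among the compounds named here.

Working notes on the cathepsin S series.

Compound 1 `CC(C)C[C@H](NC(=O)N1CCOCC1)C(=O)N[C@H](C#N)CCc1ccccc1` gives 7 nM in an assay on isolated protein for displacement of a labelled ligand from cathepsin S (Homo sapiens), read by fluorescence; a lower number here means tighter binding, a higher number weaker binding. Going by the values given here, it stands second highest of the three numbers measured so far. Among the compounds with values here, compound 2 `CC(C)CC[C@H](NC(=O)N1CCOCC1)C(=O)N[C@@H](C#N)CCc1ccccc1` gives 28 nM in this assay, a higher number than compound 1; no single-point step links the two, so only the values themselves are noted. Within the data shown here, compound 3 `CC(C)(C)C[C@H](NC(=O)N1CCOCC1)C(=O)N[C@H](C#N)CCc1ccccc1` gives 0.9 nM in this assay, and the step of a 7.8-fold lower number from compound 1 to compound 3 (0.89 log units; beyond the scatter) is the one measured step in the set that moves a single group.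

Compound 4 `Cc1ccccc1COC[C@@H](C#N)NC(=O)[C@H](CC(C)C)NC(=O)N1CCOCC1` differs from compound 1 in another part of the core: (2-methylbenzyl)oxy in place of benzyl on a saturated chain carbon, two bonds along the chain from an amide-type nitrogen and a triple-bonded carbon. Among the measured compounds shown here, no measured step bears on this change; the only step in hand, from compound 1 to compound 3, alters a different carbon and says nothing about swapping the benzyl for the (2-methylbenzyl)oxy group, which also brings one hydrogen-bond acceptor and two more heavy atoms. With nothing to anchor the direction, the expectation for compound 4 in this assay is a step of no more than modest size, and a result within the scatter of compound 1 would not surprise; the step expected is a 1.4-fold higher number from compound 1 to compound 4 (0.15 log units; within the scatter). Compound 4 is therefore estimated at 10 nM, with a range from 2 nM to 50 nM.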

Compound 4, dissociation constant: 3 nM
Estimate against measurement, compound 4: 3.3-fold (0.52 log units) above; the range from low to high includes it.
By their numbers in this assay, from the lowest: compound 3; then compound 4; then compound 1; then compound 2.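

In this assay, going by these compounds alone, this is the first measured change on the saturated chain carbon two bonds along the chain from an amide-type nitrogen and a triple-bonded carbon, and a 2.3-fold lower number from compound 1 to compound 4 (0.37 log units; beyond the scatter) shows that the number does not rise when (2-methylbenzyl)oxy replaces benzyl there. The entering group has nine heavy atoms against seven and brings one hydrogen-bond acceptor, so this place in the core accepts a larger group carrying an oxygen with binding retained and somewhat tighter, and together with the earlier step at a different carbon, a 7.8-fold lower number from compound 1 to compound 3 (0.89 log units; beyond the scatter), two separate places in the core now each give a lower number than compound 1. Nothing at hand explains why the number falls with this change.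

The change adds the chain oxygen and the ring methyl in one move, so the contribution of each stays unresolved; plain benzyloxy at this place would separate them. Also open, going by these compounds, is whether the (2-methylbenzyl)oxy group and the extra methyl of compound 3 would add up in a single compound, and how a longer chain between the oxygen and the ring would read.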